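This account rests on a few compounds, and the source may have more. Where it says the series, first, only, none or still open, it means among the compounds named here.

The account follows the move from compound 1 `COc1ccc2[nH]c(C(=O)N3CC(=O)N(Cc4ccccc4)[C@@H](CCc4ccccc4)C3)cc2c1` to compound 4 `COc1ccc2[nH]c(C(=O)N3CC(=O)N(Cc4ccccc4)[C@@H](CN4CCN(c5ccccn5)CC4)C3)cc2c1` in an ADME assay on Vero cells (Chlorocebus sabaeus) for cytotoxicity, with a stated time of 7 days; on this read-out higher numbers stand for lower toxicity in this test and lower numbers for higher toxicity in this test. Compound 1 stands at the edge of what this assay reports: it gives > 30000 nM, which is a limit rather than a number. Two neighbouring compounds give numbers. Compound 3 `COc1cccc(CN2C(=O)CN(C(=O)c3cc4cc(OC)ccc4[nH]3)C[C@@H]2CCc2ccccc2)c1`, carrying a methoxy in place of hydrogen on an aromatic carbon, gives 4500 nM, and the step of an at least 6.6-fold lower number from compound 1 to compound 3 (0.82 log units; beyond the scatter) is open on one side because compound 1 sits at the limit of > 30000 nM in this assay, at which 1 of the 3 values shown sits. Compound 2 `COc1ccc2[nH]c(C(=O)N3CC(=O)N(Cc4c[nH]c5ccccc45)[C@@H](Cc4ccccc4)C3)cc2c1` differs from compound 1 in two places; compound 2 gives 7200 nM, so the two can only be set side by side.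

Compound 4 differs from compound 1 by 4-(pyridin-2-yl)piperazin-1-yl in place of benzyl on a saturated chain carbon bound to a saturated ring carbon. Among the measured compounds shown here, no measured step touches this part of the molecule; the single step known, an at least 6.6-fold lower number from compound 1 to compound 3 (0.82 log units; beyond the scatter), concerns a methoxy on an aromatic carbon and shows only that one change can move the number beyond the scatter. With nothing to match the change, the writer expects compound 4 to give about 20000 nM in this assay, most likely between 6000 nM and 60000 nM. The expected step of an at least 1.5-fold lower number from compound 1 to compound 4 (0.17 log units; that floor lies within the scatter) is therefore a guarded one, with a fair chance that only a limit is returned.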

Compound 4, half-maximal cytotoxic concentration: > 30000 nM
Compound 4: a limit, no number (the forecaster's own chance of this, stated with the estimate: 40%); middle value at least 1.5-fold (0.17 log units) away from the limit.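

In this assay compound 4 gives > 30000 nM, which is a limit and not a number. Compound 1 also stands at a limit, so no step can be read between compound 1 and compound 4: the limit of > 30000 nM in this assay, at which 2 of the 4 values shown sit.

The compounds shown leave open whether 4-(pyridin-2-yl)piperazin-1-yl in place of benzyl moves the number at all.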